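The source may report more compounds than this note shows. Statements on the series, on what has been measured and on what is new or still open speak of the compounds shown alone.

Measured compounds:
compound 1, `C#Cc1cn([C@@H]2O[C@H](CO)[C@@H](O)[C@H]2O)c2ncnc(NC)c12`, > 20000 nM
compound 2, `C#Cc1cn([C@@H]2O[C@H](CO)[C@@H](O)[C@H]2O)c2nc(C)nc(N)c12`, > 20000 nM
compound 3, `Cc1nc(N)c2c(I)cn([C@@H]3O[C@H](CO)[C@@H](O)[C@H]3O)c2n1`, 12100 nM

In a functional assay on A549 cells (Homo sapiens), read by MTT assay, with a stated time of 72 h (on this read-out higher numbers stand for weaker inhibition and lower numbers for stronger inhibition), compound 1 gives > 20000 nM, which is a limit of the assay and not a number. Compound 2 likewise gives only a limit, > 20000 nM. Compound 3 gives 12100 nM. The step from compound 2 to compound 3 is an at least 1.6-fold lower number from compound 2 to compound 3 (0.21 log units; that floor lies within the scatter); the change is iodo in place of ethynyl on an aromatic carbon. Its floor rests on (the limit of > 20000 nM in this assay, at which 2 of the 3 values shown sit). Compound 1 and compound 2 are built from the same atoms joined differently, and the difference between their two cores is not broken down here.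

Compound 4, `CNc1ncnc2c1c(I)cn2[C@@H]1O[C@H](CO)[C@@H](O)[C@H]1O`, has not been measured. It stands to compound 1 as compound 3 stands to compound 2: iodo in place of ethynyl on an aromatic carbon, the same change at the same place. Since compound 1 gives only a limit, the step from compound 1 to compound 4 is expected to be an at least 1.3-fold lower number from compound 1 to compound 4 (0.12 log units; that floor lies within the scatter), and compound 4 is estimated at 15000 nM, between 6000 nM and 40000 nM.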

Compound 4, half-maximal inhibitory concentration: > 100000 nM
Compound 4: only a limit was reported; the forecaster's own chance of this, stated with the estimate: 40%; middle value at least 6.6-fold (0.82 log units) away from the limit.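

In this assay compound 4 gives > 100000 nM, a limit of the assay and not a number. Among the compounds shown here, compound 1 also gives only a limit, so no step between compound 1 and compound 4 can be read. The compounds shown leave open how iodo and ethynyl compare on the core of compound 1.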